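From compound 3 to compound 4: a cyclopropyl on the ring

The compounds below may be only part of what the source reports. "The series", "measured", "known", "first", "only" and "open" are said of these compounds alone.

In an assay on isolated protein for inhibition of thyroid hormone receptor beta (Homo sapiens), read by fluorescence, with a stated time of 30 min (on this read-out lower numbers stand for stronger inhibition and higher numbers for weaker inhibition), the three measured compounds stand as follows:

- compound 1, `COc1cc(C(=O)N2CCCC2)cc2nc(NCc3cccc(Cl)c3)oc12`, gives 180 nM
- compound 2, `COc1cc(C(=O)N2CCC(O)CC2)cc2nc(NCc3cccc(Cl)c3)oc12`, gives 352 nM
- compound 3, `COc1cc(C(=O)N2CCC(O)C(C)C2)cc2nc(NCc3cccc(Cl)c3)oc12`, gives 25 nM

Compound 3 holds the lowest number of the three, and both of its steps from the others are beyond the scatter: a 7.2-fold lower number from compound 1 to compound 3 (0.86 log units; beyond the scatter) and a 14-fold lower number from compound 2 to compound 3 (1.15 log units; beyond the scatter). Between the other two, a 2.0-fold higher number from compound 1 to compound 2 (0.29 log units; within the scatter), so compounds 1 and 2 cannot be ordered against each other.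

Compound 4, `COc1cc(C(=O)N2CC(C)C(O)CC2C2CC2)cc2nc(NCc3cccc(Cl)c3)oc12`, has not yet been measured. It differs from compound 3 in one place: cyclopropyl in place of hydrogen on a saturated ring carbon. Among the measured compounds shown here, none of the measured steps touches this ring carbon. For the measured compounds named here, the only step that adds a group to the same ring is the one from compound 2 to compound 3, where methyl replaced hydrogen at a different ring carbon; it was large, but it says nothing about a cyclopropyl at the position now changed. Going by the values given here, with no step of this kind on record, the expectation for compound 4 is no step beyond the scatter in this assay, so a 1.2-fold higher number from compound 3 to compound 4 (0.08 log units; within the scatter) is expected, with a wide range. Compound 4 is therefore estimated at 30 nM, between 8 nM and 120 nM.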

Compound 4, half-maximal inhibitory concentration: 8 nM
Compound 4: middle estimate off by 3.8-fold (0.57 log units), on the high side; low and high end bracket the measured number.
By their numbers in this assay, from the lowest: compound 4; then compound 3; then compounds 1 and 2 (each within the scatter of the next).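

In this assay, among the compounds shown here, cyclopropyl on the saturated ring carbon next to the ring nitrogen gives a further drop beyond the scatter (a 3.1-fold lower number from compound 3 to compound 4 (0.49 log units; beyond the scatter)), showing that this position, which no earlier step touched, can take a group of 3 heavy atoms and still lower the number already reached with the methyl group of compound 3. Against the two amides without either ring substituent, the 2-cyclopropyl-4-hydroxy-5-methylpiperidin-1-yl group stands far lower (a 44-fold lower number from compound 2 to compound 4 (1.64 log units; beyond the scatter); a 23-fold lower number from compound 1 to compound 4 (1.35 log units; beyond the scatter)), so on this ring both added groups go with lower numbers, although the cyclopropyl rests on this single case. The data shown offer no measured finding that explains why the number falls when this carbon is substituted.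

The compounds shown leave open whether an isopropyl group, a phenyl ring or an amine on a short chain at this same carbon would lower the number further or raise it again. They also leave open whether cyclopropyl would give a similar step on the 4-hydroxypiperidin-1-yl amide of compound 2, which has no methyl group.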